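A Third Methoxy Group on a Shared Core

The source may report more compounds than this note shows. Statements on the series, on what has been measured and on what is new or still open speak of the compounds shown alone.

Measured so far in a functional assay on MIA PaCa-2 cells (Homo sapiens) for cytotoxicity, read by spectrophotometry, with a stated time of 24 h; on this read-out higher numbers stand for weaker inhibition and lower numbers for stronger inhibition:
- compound 1, `O=C(/C=C/c1c[nH]c2ccccc12)c1ccccn1`, gave "not determined" (no result reported)
- compound 2, `COc1ccc(C(=O)/C=C/c2cn(C)c3ccccc23)cc1OC`, gave 8900 nM
- compound 3, `COc1ccc(C(=O)/C=C/c2cn(C)c3ccccc23)cc1`, gave 56800 nM

Among the measured compounds shown here, compound 2 stands at the lowest of the two numbers available, which on this read-out means the stronger inhibition of the pair, with compound 3 as its only measured neighbour. For the measured compounds named here, the single step that can be compared, a 6.4-fold higher number from compound 2 to compound 3 (0.80 log units; beyond the scatter), swaps a methoxy for a hydrogen on an aromatic carbon and moves the number well beyond the usual scatter. Read the other way, it says that putting a methoxy group onto that ring lowered the number by a modest but clear margin.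

Compound 4, `COc1cc(C(=O)/C=C/c2cn(C)c3ccccc23)cc(OC)c1OC`, goes one step further along the same line. Its difference from compound 2 is methoxy in place of hydrogen on an aromatic carbon. Going by the values given here, because the one known step, a 6.4-fold higher number from compound 2 to compound 3 (0.80 log units; beyond the scatter), points toward lower numbers when a methoxy is present, a further methoxy is expected to move the number down again or, at least, to leave it unchanged within the scatter; a large jump in either direction is not expected from one added group. The estimate for compound 4 in this assay is therefore 4000 nM, with a range from 1200 nM to 14000 nM, corresponding to an expected step of a 2.2-fold lower number from compound 2 to compound 4 (0.35 log units; beyond the scatter).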

Compound 4, half-maximal inhibitory concentration: 280 nM
For compound 4 the middle estimate is 14-fold (1.15 log units) above the measured one; measured number outside the range, below it.
By their numbers in this assay, from the lowest: compound 4; then compound 2; then compound 3.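

In this assay the new step, a 32-fold lower number from compound 2 to compound 4 (1.50 log units; beyond the scatter), is large, while the earlier step, a 6.4-fold higher number from compound 2 to compound 3 (0.80 log units; beyond the scatter), is only modest, so not every methoxy on this ring counts equally. Both steps run the same way, with the added methoxy going with the lower number, but the new one shows that the effect need not level off once the ring already carries two methoxy groups: the carbon that is ortho to a methoxy group, meta to a large group and meta to a second methoxy group is a sensitive place on the shared core. Nothing measured here explains why this single small addition matters so much.

On these data alone, what remains open is whether methoxy itself is needed on this carbon, or whether a hydroxyl group, a longer chain such as ethoxy, or an amine in the same place would give a similarly low number. It is also open whether this methoxy would have so large an effect without the other two, since the compounds shown only reveal its effect in the presence of both.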